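The compounds below may be only part of what the source reports. "The series", "measured", "known", "first", "only" and "open" are said of these compounds alone.

Measured so far:
compound 1 `CC(=O)Nc1ccc(S(=O)(=O)Nc2cccc(-c3nc(-c4ccc(NC(=O)c5cccnc5)cc4C(F)(F)F)no3)c2)cc1` — > 10000 nM
compound 2 `CNC(=O)Nc1ccc(S(=O)(=O)Nc2cccc(-c3nc(-c4ccc(NC(=O)c5cccnc5)cc4Cl)no3)c2)cc1` — 1300 nM
compound 3 `O=C(Nc1ccccc1)Nc1cccc(-c2nc(-c3ccc(NC(=O)c4cccnc4)cc3Cl)no2)c1` — > 10000 nM

The three compounds were tested in a functional assay on MDA-MB-231 cells (Homo sapiens) for antiproliferative activity, read by MTT assay, with a stated time of 72 h; on this read-out lower numbers stand for stronger inhibition and higher numbers for weaker inhibition. Compound 1 gives > 10000 nM, which is a limit of the assay and not a number. Compound 2 gives 1300 nM. Compound 3 gives > 10000 nM, again a limit of the assay and not a number. So compound 3 stands among the compounds for which no number is known, with only a limit shown, and that is also true of compound 1. Among the measured compounds shown here, compound 2 is the only one with a number; no step between two measured compounds can be counted here.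

Compound 4 `CS(=O)(=O)Nc1ccc(NC(=O)Nc2cccc(-c3nc(-c4ccc(NC(=O)c5cccnc5)cc4Cl)no3)c2)cc1Cl` has not yet been measured in this assay. It differs from compound 3 in one place: 3-chloro-4-(methanesulfonamido)phenyl in place of phenyl on an amide-type nitrogen.

Compound 2 carries a sulfonamide group and gives 1300 nM, which is the closest point of comparison. Compound 3 stands at a limit, so any step from it is uncertain. The step from compound 3 to compound 4 in this assay is expected to be an at least 3.3-fold lower number from compound 3 to compound 4 (0.52 log units; beyond the scatter), towards stronger inhibition. Compound 4 is estimated at 3000 nM, within a range from 600 nM to 15000 nM.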

Compound 4, half-maximal inhibitory concentration: 600 nM
For compound 4 the middle estimate is 5.0-fold (0.70 log units) above the measured one; the range from low to high includes it.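

In this assay compound 3 gives > 10000 nM, which is a limit of the assay and not a number. Putting 3-chloro-4-(methanesulfonamido)phenyl in place of phenyl on an amide-type nitrogen produces an at least 16-fold lower number from compound 3 to compound 4 (1.22 log units; beyond the scatter), the first step among these compounds that can be read at all, and it shows that activity on these cells responds strongly to what this nitrogen carries. The printed size is only a lower bound and the real step could be larger, because the starting compound sits at a limit: the limit of > 10000 nM in this assay, at which 2 of the 4 values shown sit.

The change brings in the chloro and the methanesulfonamido groups together on one ring, so the compounds shown cannot say whether one of them alone accounts for the step or whether both are needed, and a ring carrying only one of the two would be the direct test. They also leave open whether the methanesulfonamido group could give way to a different group at that place on the ring, such as a carboxylic acid or an amine, and how the number would then move.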